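The Same Methylsulfonylmethyl Step on a Second Core

This account rests on a few compounds, and the source may have more. Where it says the series, first, only, none or still open, it means among the compounds named here.

Of the compounds shown here, three have been measured in a physicochemical assay for solubility, in phosphate buffer, measured as kinetic solubility, with a stated time of 1 h, at pH 7.4; a lower number here means a less soluble compound, a higher number a more soluble compound. Compound 1 `CS(=O)(=O)Cc1cc(C2=CCOCC2)nc(-c2cccc(O)c2)n1` gives 27 ug/mL, compound 2 `Oc1cccc(-c2nccc(C3=CCOCC3)n2)c1` gives 113 ug/mL, and compound 3 `CCNC(=O)Nc1ccc(-c2nccc([C@@]34CCOC[C@@H]3C4)n2)cc1` gives 127 ug/mL. The numbers for compound 2 and compound 3 lie within the scatter of each other, while compound 1 sits beyond the scatter below both.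

Compound 1 and compound 2 differ in one place: (methylsulfonyl)methyl in place of hydrogen on an aromatic carbon. This change produced a 4.2-fold lower number from compound 2 to compound 1 (0.62 log units; beyond the scatter).

Compound 4 `CCNC(=O)Nc1ccc(-c2nc(CS(C)(=O)=O)cc([C@@]34CCOC[C@@H]3C4)n2)cc1` is not yet measured. It is related to compound 3 by the same kind of change: (methylsulfonyl)methyl in place of hydrogen on an aromatic carbon. The surroundings are not identical, though. In compound 2 the place is meta to a 3-hydroxyphenyl group (7 heavy atoms) and meta to a group of 6 heavy atoms, whereas in compound 3 it is meta to a group of 7 heavy atoms and meta to a large group. How the core of compound 2 differs from the core of compound 3 is not broken down here.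

Resting on the step from compound 2 to compound 1, the author expects a 4.2-fold lower number from compound 3 to compound 4 (0.63 log units; beyond the scatter). The estimate for compound 4 is 30 ug/mL, expected to fall between 12 ug/mL and 70 ug/mL.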

Compound 4, solubility: 77 ug/mL
Compound 4: middle estimate off by 2.6-fold (0.41 log units), on the low side; measured number outside the range, above it.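

In this assay, (methylsulfonyl)methyl in place of hydrogen on the aromatic carbon gives a 1.6-fold lower number from compound 3 to compound 4 (0.22 log units; within the scatter) on this core, whereas the same change gave a 4.2-fold lower number from compound 2 to compound 1 (0.62 log units; beyond the scatter) on the core of compound 2. A step that lay beyond the scatter on one core thus lies within it on the other, so the reading from the first pair did not hold as such for the second; with only these two pairs, however, no rule for the series follows in either direction. Nothing measured here accounts for the contrast between the two cores.

The compounds shown leave open how an amine or a carboxylic acid on the same aromatic carbon would read on either core, as both pairs carry only (methylsulfonyl)methyl there. Going by these compounds alone, they also leave open which of the differences between the two cores goes with the contrast, as no compound stands between them.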